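This account rests on a few compounds, and the source may have more. Where it says the series, first, only, none or still open, it means among the compounds named here.

Measured so far in a functional assay on MGC-803 cells (Homo sapiens) for inhibition, read by sulforhodamine B assay; a lower number here means a stronger inhibitor, a higher number a weaker inhibitor:

- Compound 1 `O=C1C=C(N2CCC2)C(=O)c2c1nc1n2[C@H]2OC[C@@H](O)[C@H]2OC1`: > 16000 nM, a limit of the assay
- Compound 2 `O=C1C=C(NC2CCCCC2)C(=O)c2c1nc1n2[C@H]2OC[C@@H](O)[C@H]2OC1`: > 8000 nM, a limit of the assay
- Compound 3 `O=C1C=C(Nc2cccc(F)c2)C(=O)c2c1nc1n2[C@H]2OC[C@@H](O)[C@H]2OC1`: 2180 nM

For the measured compounds named here, compound 3 is the strongest inhibitor of the three and the only one with an actual number, 2180 nM. Compound 4 `COc1ccc(NC2=CC(=O)c3nc4n(c3C2=O)[C@H]2OC[C@@H](O)[C@H]2OC4)cc1` carries 4-methoxyphenyl in place of 3-fluorophenyl on an amine nitrogen.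

Going by the values given here, two measured steps bear on this change, though only indirectly: an at least 7.3-fold lower number from compound 1 to compound 3 (0.86 log units; beyond the scatter) and an at least 3.6-fold lower number from compound 2 to compound 3 (0.56 log units; beyond the scatter). Both lie beyond the scatter, but each starts from a limit, so each gives only a minimum size. Both bring in the (3-fluorophenyl)amino group, and compound 4 keeps an aromatic ring on the same nitrogen. Among the compounds with values here, no measured step exchanges one such ring for another, so no step beyond the scatter is expected in this assay, and the direction remains open. The expected change is a 1.1-fold lower number from compound 3 to compound 4 (0.04 log units; within the scatter). For compound 4, the estimate is 2000 nM, with an expected range of 700 nM to 6000 nM.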

Compound 4, half-maximal inhibitory concentration: 1680 nM
Beside the measured number, compound 4's estimate is 1.2-fold (0.08 log units) above it; low and high end bracket the measured number.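

In this assay, for the compounds shown here, this is the first exchange of one aromatic ring for another on the amine nitrogen, and replacing 3-fluorophenyl with 4-methoxyphenyl gives a 1.3-fold lower number from compound 3 to compound 4 (0.11 log units; within the scatter), so these two rings cannot be told apart here. A second aromatic ring on this nitrogen also stands clear of the two non-aromatic amino groups, with an at least 4.7-fold lower number from compound 2 to compound 4 (0.67 log units; beyond the scatter) and an at least 9.5-fold lower number from compound 1 to compound 4 (0.97 log units; beyond the scatter). Both of these steps start from a limit of the assay, so they give only minimum sizes.

From the compounds shown here alone, it remains open whether the aromatic ring alone is enough, or whether a group on it is also needed, which an unsubstituted phenyl would test. A pyridine ring or a benzyl group on the same nitrogen would show how far this tolerance extends.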